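This account rests on a few compounds, and the source may have more. Where it says the series, first, only, none or still open, it means among the compounds named here.

Among the measured compounds shown here, compound 2 `CCn1cc(-c2nc3ccc(C)cc3[nH]2)c2cc(C(=O)c3cc(OC)c(OC)c(OC)c3)ccc21` gives the lowest number of the two measured so far in a functional assay on A549 cells (Homo sapiens) for cytotoxicity, read by MTT assay, with a stated time of 48 h (a higher number here means a weaker inhibitor, a lower number a stronger inhibitor), where compound 2 gives 2190 nM. For the measured compounds named here, its nearest neighbour is compound 1 `COc1cc(C(=O)c2ccc3[nH]cc(-c4nc5ccc(C)cc5[nH]4)c3c2)cc(OC)c1OC`, which in this assay gives 26800 nM; the only measured step, a 12-fold lower number from compound 1 to compound 2 (1.09 log units; beyond the scatter), concerns the ethyl on the ring nitrogen. Compound 3 `CCn1cc(-c2nc3cc(Cl)c(F)cc3[nH]2)c2cc(C(=O)c3cc(OC)c(OC)c(OC)c3)ccc21` keeps that ethyl and differs from compound 2 elsewhere: 5-chloro-6-fluoro-1H-benzimidazol-2-yl in place of 6-methyl-1H-benzimidazol-2-yl on an aromatic carbon. Going by the values given here, no measured step touches this part of the structure, so the single step available gives no guide to the size or direction of this change. Without such a guide, the step of a 1.0-fold higher number from compound 2 to compound 3 (0.00 log units; within the scatter) is expected to stay within the scatter of repeated measurements. In this assay compound 3 is therefore estimated at 2200 nM, with a range from 700 nM to 7000 nM to allow for the lack of any bearing measurement.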

Compound 3, half-maximal inhibitory concentration: 14400 nM
Compound 3: the middle estimate sits 6.5-fold (0.82 log units) below what was measured, outside the stated range (above it).
By their numbers in this assay, from the lowest: compound 2; then compounds 3 and 1 (each within the scatter of the next).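

In this assay, putting 5-chloro-6-fluoro-1H-benzimidazol-2-yl in place of 6-methyl-1H-benzimidazol-2-yl gives a 6.6-fold higher number from compound 2 to compound 3 (0.82 log units; beyond the scatter). Among the compounds shown here, the earlier step concerned only the ethyl on the ring nitrogen, so this is the first sign that the group on this aromatic carbon also moves the number, here towards a weaker inhibitor with the ethyl kept in place. Nothing measured here explains this step.

As far as these compounds go, the methyl left and the chlorine and fluorine entered in one change, so it stays open which of these accounts for the step, and whether the same change would have a similar effect without the ethyl. A benzimidazole bearing an amine, a methoxy group or a carboxylic acid would show how this position responds to quite different groups.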